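The source may hold more compounds than are shown below. What is called first, only, known or untested is meant among the compounds shown, and "the series" means these compounds.

Series notes on cytotoxicity toward rat L6 cells. Compound 1 `c1ccc(OCCCCCOc2cccc(-c3cc4ccc(C5=NCCN5)cc4o3)c2)cc1` gives, in an ADME assay on L6 cells (Rattus norvegicus) for cytotoxicity, read by resazurin assay, with a stated time of 70 h (a lower number here means a stronger inhibitor, a higher number a weaker inhibitor), 3700 nM. Compound 2 `c1ccc(OCCCCCCOc2cccc(-c3cc4ccc(C5=NCCN5)cc4o3)c2)cc1` is the same molecule with one change, (phenoxymethyl in place of phenoxy on a saturated chain carbon, five bonds along the chain from an oxygen on an aromatic ring), and in this assay compound 2 gives 1800 nM. The step of a 2.1-fold lower number from compound 1 to compound 2 (0.31 log units; beyond the scatter) is modest but beyond the scatter.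

Compound 3 `N=C(N)c1ccc2oc(-c3ccc(OCCCCOc4ccccc4)cc3)cc2c1` carries a different core; how the core of compound 3 differs from the core of compound 1 is not broken down here. In this assay compound 3 gives 1300 nM, within the scatter of compound 2 and beyond it against compound 1. Compound 4 `N=C(N)c1ccc2oc(-c3ccc(OCCCCCOc4ccccc4)cc3)cc2c1` is not yet measured. It differs from compound 3 by phenoxymethyl in place of phenoxy on a saturated chain carbon, four bonds along the chain from an oxygen on an aromatic ring. This is the same kind of change as from compound 1 to compound 2, though the place differs: five bonds along the chain from an oxygen on an aromatic ring in the first pair, four bonds in the second.

For the measured compounds named here, only one measured step of this kind exists, so the expectation for compound 4 rests on a 2.1-fold lower number from compound 1 to compound 2 (0.31 log units; beyond the scatter) alone, and is set at a 1.7-fold lower number from compound 3 to compound 4 (0.24 log units; within the scatter). Compound 4 is expected to give about 750 nM in this assay, within roughly 350 nM to 1800 nM.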

Compound 4, half-maximal inhibitory concentration: 4200 nM
Beside the measured number, compound 4's estimate is 5.6-fold (0.75 log units) below it, and the stated range ends below it.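

In this assay, phenoxymethyl in place of phenoxy on the saturated chain carbon gives a 3.2-fold higher number from compound 3 to compound 4 (0.51 log units; beyond the scatter), opposite in direction to the earlier step. Set side by side, the two steps show that this change does not carry over as a fixed shift from one core to the other: the same change on two cores in this assay, a 2.1-fold lower number (0.31 log units; beyond the scatter) from compound 1 to compound 2 and a 3.2-fold higher number (0.51 log units; beyond the scatter) from compound 3 to compound 4, 6.6-fold (0.82 log units) apart, beyond the scatter of two such steps. This does not show that the core alone sets the direction: the place also differs, five bonds along the chain from an oxygen on an aromatic ring in one pair and four bonds in the other, and with a single pair on each core the two differences cannot be separated.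

Still open, going by these compounds, is whether the direction on each core holds with a longer chain, such as 2-phenoxyethyl or 3-phenoxypropyl in the same place. Also open, on these data alone, is how a different end group, such as an amine or a carboxylic acid in place of phenoxy, would behave on either core.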